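The compounds below may be only part of what the source reports. "The series", "measured", "known", "first", "only" and "open" are said of these compounds alone.

Measured compounds in a functional assay on J774 cells (Mus musculus) for cytotoxicity, read by resazurin assay, with a stated time of 72 h; on this read-out lower numbers stand for stronger inhibition and higher numbers for weaker inhibition:

Compound 1 `O=S(=O)(Nc1cc(CO)ccc1O)c1ccc(-c2ccc(Br)cc2)cc1` gives 1000 nM
Compound 2 `O=S(=O)(Nc1cc(CO)ccc1O)c1ccc(-c2ccc(F)cc2F)cc1` gives 200 nM
Compound 3 `Cc1c(CO)cccc1NS(=O)(=O)c1ccc(-c2ccc(F)cc2F)cc1` gives 80 nM

Compound 2 and compound 1 differ in one place only: 4-bromophenyl in place of 2,4-difluorophenyl on an aromatic carbon. In this assay this change gives a 5.0-fold higher number from compound 2 to compound 1 (0.70 log units; beyond the scatter). Compound 2 and compound 3 share the same outer ring but differ at the sulfonamide nitrogen: 3-(hydroxymethyl)-2-methylphenyl in place of 2-hydroxy-5-(hydroxymethyl)phenyl on a sulfonamide nitrogen. Here the step is a 2.5-fold lower number from compound 2 to compound 3 (0.40 log units; beyond the scatter), which leaves compound 3 with the lowest number of the three measured compounds, its steps to compound 2 and to compound 1 both beyond the scatter.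

Compound 4 `Cc1c(CO)cccc1NS(=O)(=O)c1ccc(-c2ccc(Br)cc2)cc1` has not yet been measured in this assay. It stands to compound 3 as compound 1 stands to compound 2: 4-bromophenyl in place of 2,4-difluorophenyl on an aromatic carbon. The place of the change is described in the same words for both pairs, so it is the same change made on a different core, and the cores differ as described for compound 2 and compound 3. Among the compounds shown this change occurs twice, and only once has it been measured.

On the expectation that the step seen from compound 2 to compound 1, a 5.0-fold higher number from compound 2 to compound 1 (0.70 log units; beyond the scatter), carries over to the core of compound 3, compound 4 is expected to show a 5.0-fold higher number from compound 3 to compound 4 (0.70 log units; beyond the scatter) in this assay. The estimate for compound 4 in this assay is therefore 400 nM, expected to fall between 150 nM and 1000 nM, with the width reflecting that the step rests on a single measured pair.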

Compound 4, half-maximal inhibitory concentration: 750 nM
Estimate against measurement, compound 4: 1.9-fold (0.27 log units) below; measured number inside the range.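

On the second core the same change gives a 9.4-fold higher number from compound 3 to compound 4 (0.97 log units; beyond the scatter) in this assay, so the number rises on both cores when 4-bromophenyl takes the place of 2,4-difluorophenyl. Set side by side, the two steps do not differ by more than repeated measurements of this kind would allow: the same change on two cores in this assay, a 5.0-fold higher number (0.70 log units; beyond the scatter) from compound 2 to compound 1 and a 9.4-fold higher number (0.97 log units; beyond the scatter) from compound 3 to compound 4, 1.9-fold (0.27 log units) apart, within the scatter of two such steps. Among the compounds shown here, in this series the change therefore carried over between these two cores in direction and, within the scatter, in size, but with only two pairs this does not show that it would carry over to any other core, and it does not tell what lies behind the step.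

The compounds shown have only 2,4-difluorophenyl or 4-bromophenyl on the outer ring, so it remains open how other groups at that place, such as a nitrile, an amine or a carboxylic acid, would behave on either core. For the compounds shown here, only two groups appear on the sulfonamide nitrogen, so it is also open whether the step would keep its direction and size if the hydroxymethyl group gave way to a longer chain or a carboxylic acid.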